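Fluorine added to the anilino ring of compound 1

The compounds below may be only part of what the source reports. "The series", "measured", "known", "first", "only" and "open" are said of these compounds alone.

Measured so far: compound 1 `Cc1n[nH]c2ccc(-c3nc4cnc(N5CCN(C)CC5)cn4c3Nc3ccc(Cl)cc3)cc12`, 3510 nM; compound 2 `COc1ccc(Nc2c(-c3ccc4[nH]nc(C)c4c3)nc3cnc(N4CCN(C)CC4)cn23)cc1`, "not determined" (no result reported) in a functional assay on MV4-11 cells (Homo sapiens) for inhibition, with a stated time of 120 h (a lower number here means a stronger inhibitor, a higher number a weaker inhibitor), so no result is reported for it.

For the measured compounds named here, compound 1 stands as the only compound with a number in this assay, a weak inhibitor. Compound 3 `Cc1n[nH]c2ccc(-c3nc4cnc(N5CCN(C)CC5)cn4c3Nc3ccc(F)c(Cl)c3)cc12` carries 3-chloro-4-fluorophenyl in place of 4-chlorophenyl on a nitrogen on an aromatic ring. Going by the values given here, no measured pair shows this kind of change, so the size of its effect is unknown. Compound 3 is expected to stay close to compound 1, with the step of a 1.2-fold lower number from compound 1 to compound 3 (0.07 log units; within the scatter) not clearly beyond the scatter in either direction. The estimated value for compound 3 is 3000 nM, within 1200 nM to 8000 nM.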

Compound 3, half-maximal inhibitory concentration: 2850 nM
For compound 3 the middle estimate is 1.1-fold (0.02 log units) above the measured one; low and high end bracket the measured number.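

Set beside 4-chlorophenyl, 3-chloro-4-fluorophenyl on a nitrogen on an aromatic ring gives a 1.2-fold lower number from compound 1 to compound 3 (0.09 log units; within the scatter) in this assay. Compound 1 and compound 3 therefore cannot be told apart, and this position accepts the larger ring substituent pattern without a step beyond the scatter. No evidence is available that bears on this result.

Both compounds keep a halogenated phenyl here, so this step says nothing about other kinds of group. On these data alone, whether an amine or a carboxylic acid on this ring would move the number beyond the scatter remains open.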